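Indane imidazoles: donor substituents on the aromatic ring

The compounds below may be only part of what the source reports. "The series", "measured", "known", "first", "only" and "open" are said of these compounds alone.

Measured so far in a functional assay on CHO cells for agonist activity at Alpha-1D adrenergic receptor (Homo sapiens), read by FLIPR and calcium flux; on this read-out lower numbers stand for an effect already at smaller amounts and higher numbers for an effect only at larger amounts of compound:
compound 1 `c1ccc(-c2cccc3c2CCC3c2ncc[nH]2)nc1` gives > 10000 nM
compound 2 `c1cc(-c2ccn[nH]2)c2c(c1)C(c1ncc[nH]1)CC2` gives 336 nM
compound 3 `CCS(=O)(=O)Nc1cccc(Cc2c[nH]cn2)c1` gives > 10000 nM

The value of compound 1 is a limit of this assay, not a number; the same holds for compound 3 (the limit of > 10000 nM in this assay, at which 2 of the 3 values shown sit). Compound 4 `CS(=O)(=O)Nc1cccc2c1CCC2c1ncc[nH]1` differs from compound 1 by methanesulfonamido in place of pyridin-2-yl on an aromatic carbon. Among the compounds with values here, the one step that bears on this change is an at least 29-fold lower number from compound 1 to compound 2 (1.47 log units; beyond the scatter), where a ring bearing a hydrogen-bond donor replaced pyridin-2-yl at the same place. Methanesulfonamido likewise brings one hydrogen-bond donor, so a step towards a lower number is expected, though less securely than for compound 2, since compound 3 on a different core carries a related group and only reaches the limit. For compound 4 a step of an at least 6.6-fold lower number from compound 1 to compound 4 (0.82 log units; beyond the scatter) is estimated, giving an expected value of 1500 nM with a range from 200 nM to 10000 nM.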

Compound 4, half-maximal effective concentration: > 10000 nM
Compound 4: only a limit was reported; the forecaster's own chance of this, stated with the estimate: 35%; middle value at least 6.6-fold (0.82 log units) from the limit.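

In this assay compound 4 gives > 10000 nM, which is a limit of the assay and not a number. At this aromatic carbon, methanesulfonamido does not reproduce the result of 1H-pyrazol-5-yl, with an at least 29-fold higher number from compound 2 to compound 4 (1.47 log units; beyond the scatter), so a hydrogen-bond donor entering here does not by itself give a measurable value. The step between compound 1 and compound 4 cannot be read, and most of the series now sits at the limit: the limit of > 10000 nM in this assay, at which 3 of the 4 values shown sit.

As far as these compounds go, it remains open whether the value of compound 2 depends on the ring of 1H-pyrazol-5-yl or on its donor. A simple amine or a hydroxyl group at this carbon of the shared core could help separate the two.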